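Methoxy for chloro on a dinitrophenyl ether urea

The compounds below may be only part of what the source reports. "The series", "measured", "known", "first", "only" and "open" are said of these compounds alone.

Measured compounds:
compound 1, `Nc1ccc(Oc2ccccc2-c2ccc(S(=O)(=O)NCCNC(=O)Nc3ccc(Cl)cc3)s2)cc1`, > 20000 nM (a limit of the assay)
compound 2, `O=C(NCCNS(=O)(=O)c1ccc(-c2ccccc2OCc2ccccc2)s1)Nc1cc(C(F)(F)F)cc(C(F)(F)F)c1`, 13500 nM
compound 3, `O=C(NCCNS(=O)(=O)c1ccc(-c2ccccc2Oc2ccc([N+](=O)[O-])c([N+](=O)[O-])c2)s1)Nc1ccc(Cl)cc1`, > 20000 nM (a limit of the assay)

Of the compounds shown here, three sharing one core have been tested in a functional assay on HeLa cells (Homo sapiens) for inhibition, read by CCK-8 assay, with a stated time of 48 h; on this read-out higher numbers stand for weaker inhibition and lower numbers for stronger inhibition. Compound 1 reaches only a limit of the assay, giving > 20000 nM. In this assay compound 2 gives 13500 nM. Compound 3 also stops at a limit of the assay, at > 20000 nM. The step that the two limits leave unreadable from compound 1 to compound 3 cannot be read, since both ends sit at a limit, as the limit of > 20000 nM in this assay, at which 2 of the 3 values shown sit, shows. Compound 3 therefore stands among the weakest readings shown, with no number of its own.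

Compound 4, `COc1ccc(NC(=O)NCCNS(=O)(=O)c2ccc(-c3ccccc3Oc3ccc([N+](=O)[O-])c([N+](=O)[O-])c3)s2)cc1`, differs from compound 3 only in one place: methoxy in place of chloro on an aromatic carbon. No measured step touches this change, so nothing shown gives its size or direction. The reading of compound 3 is itself a limit, so the expected step that the limit leaves unreadable from compound 3 to compound 4 is estimated to stay within the scatter. Compound 4 is thus expected to give about 25000 nM in this assay, in a range from 8000 nM to 80000 nM, most likely again as a limit.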

Compound 4, half-maximal inhibitory concentration: > 20000 nM
Compound 4 was reported as a limit; the forecaster's own chance of this, stated with the estimate: 70%; the middle value lies beyond the limit too.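

Compound 3 and compound 4 both stop at a limit, so the step between them cannot be read: the limit of > 20000 nM in this assay, at which 3 of the 4 values shown sit. The compounds shown leave open whether methoxy in place of chloro on an aromatic carbon changes inhibition at all, in size or in direction.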